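Halogenated benzyl variation on the piperazine sulfonamide series

This account rests on a few compounds, and the source may have more. Where it says the series, first, only, none or still open, it means among the compounds named here.

Measured so far in an assay on CHO cells for displacement of a labelled ligand from adenosine receptor A1 (Homo sapiens); on this read-out higher numbers stand for weaker inhibition and lower numbers for stronger inhibition:
compound 1 `Cn1c(=O)c2[nH]c(-c3ccc(S(=O)(=O)N4CCN(Cc5ccc(Cl)s5)CC4)cc3)cc2n(C)c1=O`: 102 nM
compound 2 `CCn1c(=O)c2[nH]c(-c3ccc(S(=O)(=O)NC4CCN(Cc5ccc(F)cc5)CC4)cc3)cc2n(CC)c1=O`: 205 nM
compound 3 `Cn1c(=O)c2[nH]c(-c3ccc(S(=O)(=O)N4CCN(Cc5ccc(Br)cc5)CC4)cc3)cc2n(C)c1=O`: 183 nM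

Compound 3 gives 183 nM in this assay; compound 2 lies within the scatter of it, and compound 1 also lies within the scatter of it. Compound 4 `Cn1c(=O)c2[nH]c(-c3ccc(S(=O)(=O)N4CCN(Cc5ccc(F)cc5F)CC4)cc3)cc2n(C)c1=O` carries 2,4-difluorophenyl in place of 4-bromophenyl on a saturated chain carbon bound to an amine nitrogen in a ring. Within the data shown here, the one measured step that bears on this, a 1.8-fold higher number from compound 1 to compound 3 (0.25 log units; within the scatter), also exchanges one halogenated aryl for another on the same carbon and stays within the scatter. On that basis no step beyond the scatter is expected for a 1.0-fold lower number from compound 3 to compound 4 (0.01 log units; within the scatter). Compound 4 is therefore estimated at 180 nM in this assay, with a range from 70 nM to 450 nM.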

Compound 4, half-maximal inhibitory concentration: 126 nM
Estimate against measurement, compound 4: 1.4-fold (0.15 log units) above; the measured number falls inside the stated range.
By their numbers in this assay, from the lowest: compounds 1, 4, 3 and 2 (each within the scatter of the next).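

In this assay 2,4-difluorophenyl in place of 4-bromophenyl gives a 1.5-fold lower number from compound 3 to compound 4 (0.16 log units; within the scatter), and 2,4-difluorophenyl in place of 5-chlorothiophen-2-yl gives a 1.2-fold higher number from compound 1 to compound 4 (0.09 log units; within the scatter). At this position, on a saturated chain carbon bound to an amine nitrogen in a ring, a third halogenated aryl, now with two fluorines, therefore also produces no step beyond the scatter. No supporting data bear on this result.

Open, from the compounds shown here alone, is whether an unsubstituted phenyl, a pyridine ring or a carboxylic acid on the aryl ring would give a step beyond the scatter. Compound 2 differs from these compounds in more than one place, so it cannot settle this.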